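This account rests on a few compounds, and the source may have more. Where it says the series, first, only, none or still open, it means among the compounds named here.

Of the compounds shown here, three have so far been measured in a functional assay on PC-3 cells (Homo sapiens) for cytotoxicity, read by MTT assay, with a stated time of 72 h; a lower number here means a stronger inhibitor, a higher number a weaker inhibitor. Compound 1 `O=C(N/N=C/c1cccc(Cl)c1Cl)Nc1cc2c(Nc3ccc(F)c(Cl)c3)ncnc2cc1O[C@H]1CCOC1` gives 27400 nM. Compound 3 `COc1cc2ncnc(Nc3ccc(F)c(Cl)c3)c2cc1NC(=O)N/N=C/c1cccc(Cl)c1Cl` differs from compound 1 by methyl in place of oxolan-3-yl on an oxygen on an aromatic ring. In this assay compound 3 gives 24400 nM, and the step between the two is a 1.1-fold lower number from compound 1 to compound 3 (0.05 log units; within the scatter). Compound 2 `CC(C)(C)c1cc(/C=N/NC(=O)Nc2cc3c(Nc4ccc(F)c(Cl)c4)ncnc3cc2O[C@H]2CCOC2)cc(C(C)(C)C)c1O` gives 13100 nM; how its core differs from the core of compound 1 is not broken down here. Its gap to compound 3 lies within the scatter, while its gap to compound 1 lies beyond it.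

Compound 4 `COc1cc2ncnc(Nc3ccc(F)c(Cl)c3)c2cc1NC(=O)N/N=C/c1cc(C(C)(C)C)c(O)c(C(C)(C)C)c1` is not yet measured. It arises from compound 2 by methyl in place of oxolan-3-yl on an oxygen on an aromatic ring, the same change that turned compound 1 into compound 3, made at the same place: on an oxygen on an aromatic ring whose other neighbour is an aromatic carbon. Because that earlier step was a 1.1-fold lower number from compound 1 to compound 3 (0.05 log units; within the scatter), the expected step here is a 1.1-fold lower number from compound 2 to compound 4 (0.04 log units; within the scatter), with the value of compound 2 as the starting point. On that basis compound 4 is estimated to give 12000 nM, most likely lying between 5000 nM and 30000 nM.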

Compound 4, half-maximal inhibitory concentration: 28700 nM
Estimate against measurement, compound 4: 2.4-fold (0.38 log units) below; the range from low to high includes it.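

In this assay, putting methyl in place of oxolan-3-yl on an oxygen on an aromatic ring gives a 2.2-fold higher number from compound 2 to compound 4 (0.34 log units; beyond the scatter), whereas the same change on the other core gave a 1.1-fold lower number from compound 1 to compound 3 (0.05 log units; within the scatter). One step lies within the usual scatter and the other beyond it, yet set side by side the two cannot be told apart: the same change on two cores in this assay, a 1.1-fold lower number (0.05 log units; within the scatter) from compound 1 to compound 3 and a 2.2-fold higher number (0.34 log units; beyond the scatter) from compound 2 to compound 4, 2.5-fold (0.39 log units) apart, within the scatter of two such steps So, as far as these measurements can resolve, the change behaves alike on both cores, but two pairs cannot prove that it is independent of the core, and a real difference of this modest size could go unseen.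

Going by these compounds, only oxolan-3-yl and methyl appear on that oxygen here, so it remains open whether a longer chain, or a chain ending in an amine, would shift the number on either core. Also open, on these data alone, is how the same change would behave on a third core.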